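The source may hold more compounds than are shown below. What is called first, only, known or untested is meant among the compounds shown, and "the series" means these compounds.

Of the compounds shown here, two have been measured so far. Compound 1 `CCN(C[C@H]1COC(N)=N1)c1ccccc1` gives 59 nM in a functional assay on HEK293 cells for agonist activity at trace amine-associated receptor 1 (Homo sapiens), read by cAMP accumulation, with a stated time of 30 min; on this read-out lower numbers stand for an effect already at smaller amounts and higher numbers for an effect only at larger amounts of compound. Compound 2 `NC1=N[C@@H](CNc2cccc(Cl)c2)CO1` gives 580 nM in this assay, the higher of the two values, with compound 1 giving a lower number, a gap beyond the usual scatter.

Compound 3 `CCN(C[C@H]1COC(N)=N1)c1cccc(Cl)c1` has not yet been measured. It differs from compound 2 by ethyl in place of hydrogen on a nitrogen on an aromatic ring. Going by the values given here, no step of exactly this kind between two measured compounds is available, so the expected size of the change rests on the values themselves. Compound 1, whose nitrogen also carries an ethyl group, gives 59 nM, which suggests the core accepts an ethyl on this nitrogen while keeping a low number. For compound 3 the expected step is a 5.3-fold lower number from compound 2 to compound 3 (0.72 log units; beyond the scatter), a move toward lower numbers beyond the scatter. Compound 3 is therefore estimated at 110 nM, within a range from 30 nM to 400 nM.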

Compound 3, half-maximal effective concentration: 29 nM
For compound 3 the middle estimate is 3.8-fold (0.58 log units) above the measured one; measured number outside the range, below it.
By their numbers in this assay, from the lowest: compound 3; then compound 1; then compound 2.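

In this assay ethyl in place of hydrogen on the nitrogen on the aromatic ring gives a 20-fold lower number from compound 2 to compound 3 (1.30 log units; beyond the scatter) and marks this nitrogen as a place where a small substituent has a large effect on the number. Chloro in place of hydrogen on an aromatic carbon gives a 2.0-fold lower number from compound 1 to compound 3 (0.31 log units; beyond the scatter) and so, with ethyl on the nitrogen, moves the number modestly lower rather than higher. Of the two single changes that lead to compound 3, the one on the nitrogen is the larger.

As far as these compounds go, how a methyl group or a longer chain such as propyl on this nitrogen compares with ethyl stays open, as does how fluoro or methoxy on that aromatic carbon compares with chloro. Nothing given here accounts for either step.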